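Swapping methyl for tert-butyl on an aromatic carbon

The source may report more compounds than this note shows. Statements on the series, on what has been measured and on what is new or still open speak of the compounds shown alone.

Compound 1 `CCc1nc2ccc(Cl)cn2c1C(=O)NCc1ccc2c(c1)CCN(Cc1cc(F)cc(F)c1)C2`: 14 ug/mL
Compound 2 `CCc1nc2ccc(Cl)cn2c1C(=O)NCc1ccc2c(c1)CCN(Cc1ccc(F)cc1)C2`: > 64 ug/mL
Compound 3 `CCc1nc2ccc(Cl)cn2c1C(=O)NCc1ccc2c(c1)CCN(Cc1ccc(C)cc1)C2`: 51 ug/mL

These values come from an ADME assay on Vero cells (Chlorocebus sabaeus) for cytotoxicity, read by MTT assay, with a stated time of 72 h (on this read-out lower numbers stand for higher toxicity in this test and higher numbers for lower toxicity in this test), and the three compounds differ only in the aromatic group at one end of the shared core. Compound 2 reads > 64 ug/mL, which is a limit of the assay and not a number. Compound 3, at 51 ug/mL, has the higher of the two true numbers, and the gap to the other is a 3.6-fold higher number from compound 1 to compound 3 (0.56 log units; beyond the scatter), beyond the scatter.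

Next comes compound 4 `CCc1nc2ccc(Cl)cn2c1C(=O)NCc1ccc2c(c1)CCN(Cc1ccc(C(C)(C)C)cc1)C2`, with tert-butyl in place of methyl on an aromatic carbon. Within the data shown here, no measured step enlarges this group, so the evidence is indirect. The closest step, an at least 1.2-fold lower number from compound 2 to compound 3 (0.09 log units; that floor lies within the scatter), is a swap on the same aromatic carbon, and its floor lies within the scatter. The step of an at least 4.5-fold higher number from compound 1 to compound 2 (0.66 log units; beyond the scatter) shows that changes to this aromatic group can matter. A small fall in this assay is therefore expected, although a drop towards compound 1 at 14 ug/mL remains possible. The expected change is a 1.4-fold lower number from compound 3 to compound 4 (0.15 log units; within the scatter), which would stay within the scatter. For compound 4 the estimate is 36 ug/mL, with an expected range of 13 ug/mL to 64 ug/mL.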

Compound 4, half-maximal cytotoxic concentration: 37 ug/mL
The estimate for compound 4 lay 1.0-fold (0.01 log units) below the measured number; the range from low to high includes it.
By their numbers in this assay, from the lowest: compound 1; then compounds 4 and 3 (each within the scatter of the next). At a limit, above all of these: compound 2.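

In this assay, tert-butyl brings 4 heavy atoms to the aromatic carbon where methyl brought 1, and the outcome is a 1.4-fold lower number from compound 3 to compound 4 (0.14 log units; within the scatter): at this place, para to a large group, a much bulkier carbon group gives no change that can be told from the scatter. The 4-(tert-butyl)phenyl group also stays apart from the 3,5-difluorophenyl group, with a 2.6-fold higher number from compound 1 to compound 4 (0.42 log units; beyond the scatter), so each of the three compounds with one group on this ring, compounds 2, 3 and 4, reads higher than compound 1, and none shown goes against this. Compound 2 carries a limit of the assay and not a number, so an at least 1.7-fold lower number from compound 2 to compound 4 (0.23 log units; that floor lies within the scatter) gives only a floor, and how far the fluoro and tert-butyl compounds truly lie apart stays unknown: the limit of > 64 ug/mL in this assay, at which 1 of the 4 values shown sits.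

The compounds shown do not tell whether the lower number of compound 1 comes from having two fluoro groups or from where they sit on the ring. They also leave open how this assay would respond to an amine, a carboxylic acid or a methoxy group on the same aromatic carbon, since only fluoro, methyl and tert-butyl appear there.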